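Phenyl for chlorophenyl-ethenyl on the shared core

The source may hold more compounds than are shown below. What is called first, only, known or untested is meant among the compounds shown, and "the series" means these compounds.

The series is read in an assay on CHO cells for displacement of a labelled ligand from adenosine receptor A1 (Homo sapiens), read by scintillation counting, tested at 10 uM; a higher number here means more inhibition at the concentration tested (going by the name of the read-out), a lower number less inhibition. Compound 1, `Nc1sc(-c2ccccc2)c(-c2ccccc2)c1C(=O)c1ccc(Cl)cc1`, gives 1%. Compound 2, `CC(C)(C)Cc1c(/C=C/c2ccc(Cl)cc2)sc(N)c1C(=O)c1ccc(Cl)cc1`, gives 1%. Compound 3, `CC(C)(C)Cc1c(Br)sc(N)c1C(=O)c1cccc(Cl)c1`, gives 1%. Compound 2 thus stands level with compounds 1 and 3 at the digits shown; its nearest neighbour is compound 1 and its furthest is compound 3, and both gaps lie within the usual scatter of repeated measurements. For the measured compounds named here, no pair of measured compounds differs in a single place, so the measured set shows no step that ties one structural change to a movement in this assay.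

Compound 4, `CC(C)(C)Cc1c(-c2ccccc2)sc(N)c1C(=O)c1ccc(Cl)cc1`, is yet to be measured in this assay. It differs from compound 2 in one place: phenyl in place of 2-(4-chlorophenyl)ethenyl on an aromatic carbon. Compound 1 also bears a phenyl group and gives 1%, which sits within the scatter of compound 2 at 1%. With all three measured compounds at the same low level, no movement beyond the scatter is expected from this change, and the estimated step is a number 1 percentage points higher from compound 2 to compound 4 (within the scatter). Compound 4 is expected to give 2%, with a range from -8% to 12%.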

Compound 4, a percentage reported as inhibition, at one concentration (the size of the read-out at that concentration, not a potency): 1%
For compound 4 the middle estimate is 1 percentage points above the measured one; measured number inside the range.
By their numbers in this assay, from the lowest: compounds 1, 2, 3 and 4 (each within the scatter of the next).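

In this assay, for the compounds shown here, phenyl in place of 2-(4-chlorophenyl)ethenyl on the aromatic carbon next to the ring sulfur gives no change at the digits printed from compound 2 to compound 4 (within the scatter); this is the first single-place reading at this position, and it shows no response to losing the double bond outside aromatic rings and the chlorine. Neopentyl in place of phenyl on an aromatic carbon gives no change at the digits printed from compound 1 to compound 4 (within the scatter), so this second single-place change leaves the read-out just as flat. Nothing available explains either step.

All four compounds sit at the same low level, so these steps cannot show whether either position would matter in a compound with clear inhibition at the concentration tested. Still open, going by these compounds, is whether an amine or a carboxylic acid on the phenyl next to the ring sulfur, or a longer chain in place of neopentyl, would move the number beyond the scatter.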